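Ester group swap in a THP-1 growth inhibition series

A few compounds are considered here, and "the series" means these few. Any claim that something is new, unique, unknown or untested is made for them only; others in the source may bear on it.

Compounds measured so far:
compound 1, `COc1cc(O)c(C(=O)OCC2CCCCC2)c(/C=C/CN2C(=O)C=CC2=O)c1`, 5.9%
compound 2, `C=CS(=O)(=O)NC/C=C/c1cc(OC)cc(O)c1C(=O)OCc1ccc(Br)cc1`, 31.2%
compound 3, `C=CS(=O)(=O)NC/C=C/c1cc(OC)cc(O)c1C(=O)OCC1CCCCC1`, 26.5%

In a functional assay on THP-1 cells (Homo sapiens) for inhibition, read by luminescence, with a stated time of 72 h, tested at 5 uM (a higher number here means more inhibition of growth at the concentration tested, a lower number less inhibition of growth), compound 3 gives 26.5%, the second highest of the three numbers. Its nearest neighbour is compound 2, with a difference that stays within the scatter, a number 4.7 percentage points lower from compound 2 to compound 3 (within the scatter). Compound 1 lies furthest away, a number 20.6 percentage points higher from compound 1 to compound 3 (beyond the scatter), a step that concerns the group on the saturated chain carbon bound to a double-bonded chain carbon and so says nothing about the ester end of the molecule.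

The unmeasured compound 4, `C=CS(=O)(=O)NC/C=C/c1cc(OC)cc(O)c1C(=O)OCc1ccc(F)cc1`, differs from compound 3 at that ester end: 4-fluorophenyl in place of cyclohexyl on a saturated chain carbon bound to an oxygen next to a carbonyl group. Among the compounds with values here, the only step that bears on it is the one between compound 2 and compound 3, where cyclohexyl replaced 4-bromophenyl and the number moved by a number 4.7 percentage points lower from compound 2 to compound 3 (within the scatter), inside the scatter. Going the other way, from a cyclohexyl to a halogen-bearing phenyl, is therefore expected to give at most a small upward shift, a number 3.5 percentage points higher from compound 3 to compound 4 (within the scatter), and quite possibly none beyond the scatter.

Compound 4 is accordingly estimated at 30% in this assay, with a range from 18% to 42%.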

Compound 4, percent growth inhibition at one concentration: 41.7%
Compound 4: middle estimate off by 11.7 percentage points, on the low side; measured number inside the range.
By their numbers in this assay, from the lowest: compound 1; then compounds 3 and 2 (each within the scatter of the next); then compound 4.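

In this assay, the ester end now proves able to shift growth inhibition: the earlier swap of 4-bromophenyl for cyclohexyl had stayed within the scatter, whereas 4-fluorophenyl in place of cyclohexyl gives a number 15.2 percentage points higher from compound 3 to compound 4 (beyond the scatter). An aromatic ring at this place is therefore not enough on its own, since compound 2 also carries one and remains within the scatter of compound 3, and the halogen on that ring separates the two aryl esters, with fluoro in place of bromo giving a number 10.5 percentage points higher from compound 2 to compound 4 (beyond the scatter). Nothing shown here accounts for either shift.

As far as these compounds go, without an unsubstituted benzyl ester or a 4-chlorophenyl analogue, it remains open whether fluoro raises the number relative to no halogen at all, or whether bromo lowers it, and how the other halogens would fall. From the compounds shown here alone, it is also open whether an amine or a carboxylic acid on the ring would be tolerated at this place, and whether the gain from 4-fluorophenyl would carry over to the chain group of compound 1.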